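The source may report more compounds than this note shows. Statements on the series, on what has been measured and on what is new or still open speak of the compounds shown alone.

Compound 1 `Cc1ccc(Nc2ccc3c(c2)C(O)(CCC(C)C)C(=O)N3)cc1` gives 12500 nM in a functional assay on A549 cells (Homo sapiens) for antiproliferative activity, read by MTT assay, with a stated time of 48 h; a higher number here means a weaker inhibitor, a lower number a stronger inhibitor.
Compound 2 `CCCCCCC1(O)C(=O)Nc2ccc(Nc3ccc(C)cc3)cc21` gives 12100 nM in this assay.
Compound 3 `CC(C)CCC1(O)C(=O)Nc2ccc(Nc3ccc(C(F)(F)F)cc3)cc21` gives 4200 nM in this assay.

Compound 4 `CCCCCCC1(O)C(=O)Nc2ccc(Nc3ccc(C(F)(F)F)cc3)cc21` has not yet been measured. It arises from compound 3 by a single change, (butyl in place of isopropyl on a saturated chain carbon, two bonds along the chain from a saturated ring carbon). The same change has been made once before, from compound 1 to compound 2, as butyl in place of isopropyl on a saturated chain carbon, two bonds along the chain from a saturated ring carbon, where it gave a 1.0-fold lower number from compound 1 to compound 2 (0.01 log units; within the scatter). The two cores on which the change is made differ by trifluoromethyl in place of methyl on an aromatic carbon, and that difference gave a 3.0-fold lower number from compound 1 to compound 3 (0.47 log units; beyond the scatter). A small step is expected again for compound 4 because a 1.0-fold lower number from compound 1 to compound 2 (0.01 log units; within the scatter) lay within the scatter, so the expected step is no change at the digits printed from compound 3 to compound 4 (within the scatter). Compound 4 is therefore estimated at 4200 nM. For the measured compounds named here, its value is expected to fall between 2000 nM and 9000 nM, a range kept wide since only one earlier instance of this change is known.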

Compound 4, half-maximal inhibitory concentration: 2800 nM
Compound 4: the middle estimate sits 1.5-fold (0.18 log units) above what was measured, and the stated range covers the measured number.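

In this assay, butyl in place of isopropyl gives a 1.5-fold lower number from compound 3 to compound 4 (0.18 log units; within the scatter), which lies within the scatter and agrees with the same change on the core of compound 1: the same change on two cores in this assay, a 1.0-fold lower number (0.01 log units; within the scatter) from compound 1 to compound 2 and a 1.5-fold lower number (0.18 log units; within the scatter) from compound 3 to compound 4, 1.5-fold (0.16 log units) apart, within the scatter of two such steps
Trifluoromethyl in place of methyl gives a 4.3-fold lower number from compound 2 to compound 4 (0.64 log units; beyond the scatter), a step beyond the scatter that also agrees with its earlier counterpart: the same change on two cores in this assay, a 3.0-fold lower number (0.47 log units; beyond the scatter) from compound 1 to compound 3 and a 4.3-fold lower number (0.64 log units; beyond the scatter) from compound 2 to compound 4, 1.5-fold (0.16 log units) apart, within the scatter of two such steps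
Each change therefore carried over between these two cores about unchanged, but this rests on a single pair of steps per change in this one assay, and it shows neither why the steps have this size nor that they would hold on other cores.

Still open, going by these compounds, is whether a longer chain, such as octyl, would also leave the number unchanged within the scatter. Also open, on these data alone, is how a nitrile or an amine in place of trifluoromethyl on that aromatic carbon would compare.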